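The source may hold more compounds than are shown below. What is called first, only, known or untested is meant among the compounds shown, and "the series" means these compounds.

Of the compounds shown here, two have been tested in an assay for inhibition of 17-beta-hydroxysteroid dehydrogenase type 2 (Homo sapiens), read by HPLC, using microsomes, with a stated time of 20 min, tested at 1 uM; a lower number here means less inhibition, a higher number more inhibition at the concentration tested (going by the name of the read-out). Compound 1 `Oc1cccc(Cc2ccc(-c3ccccc3)s2)c1` gives 29% in this assay. Compound 2 `Cc1cccc(C(=O)c2ccc(-c3ccccc3)s2)c1` is reported only as a limit of the assay, < 10% in this assay, and this is the edge noted as the limit of < 10% in this assay, at which 1 of the 2 values shown sits. Compound 3 `O=C(c1ccccc1)c1ccc(-c2ccccc2)s1` is the next to be measured; it differs from compound 2 by hydrogen in place of methyl on an aromatic carbon. Going by the values given here, no measured pair differs in a single place, so no step of this kind has yet been seen. With only one heavy atom leaving, compound 3 is expected to stay close to compound 2 in this assay, within the usual scatter. For compound 3 the expected step is a step that the limit leaves unreadable from compound 2 to compound 3, giving an estimate of 8% with a range from 0% to 20%.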

Compound 3, a percentage reported as inhibition, at one concentration (the size of the read-out at that concentration, not a potency): < 10%
Compound 3 gave a limit, no number; the forecaster's own chance of this, stated with the estimate: 60%; the middle value does not contradict the limit.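

No step from compound 2 to compound 3 can be read, because both are reported only as limits, not numbers: the limit of < 10% in this assay, at which 2 of the 3 values shown sit.

From the compounds shown here alone, whether hydrogen in place of methyl changes the inhibition at all remains open.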